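The source may report more compounds than this note shows. Statements on the series, on what has been measured and on what is new or still open speak of the compounds shown alone.

Compound 1 `O=C(O)CC[C@H](NC(=O)CN(c1nc(Cl)nc2[nH]cnc12)C1CC1)C(=O)O` gives 44.7%
Compound 2 `O=C(O)C[C@H](NC(=O)CN(c1nc(Cl)nc2[nH]cnc12)C1CC1)C(=O)O` gives 25.1%
Compound 3 `CC(C)[C@H](NC(=O)CN(c1nc(Cl)nc2[nH]cnc12)C1CC1)C(=O)O` gives 30.3%

All three share one core and differ only in the group on a saturated chain carbon bound to an amide-type nitrogen and a carbonyl carbon. In a functional assay on the whole organism (Tail, strain ICR) with Mus musculus as the target, in the tail flick test, with a stated time of 90 min, at a dose of 25 umol/kg by the oral route (on this read-out higher numbers stand for a stronger effect at the one dose given and lower numbers for a weaker effect), compound 3 stands second highest of the three numbers: compound 1 lies higher, as a number 14.4 percentage points lower from compound 1 to compound 3 (beyond the scatter) shows, while compound 2 sits within the scatter of it, as a number 5.2 percentage points higher from compound 2 to compound 3 (within the scatter) shows. Compound 4 `O=C(O)CNC(=O)CN(c1nc(Cl)nc2[nH]cnc12)C1CC1` strips that group away: hydrogen in place of isopropyl on a saturated chain carbon bound to an amide-type nitrogen and a carbonyl carbon. The two steps that bear on this change both vary the same group, one beyond the scatter and one within it, and neither shows what losing the group entirely does. No step beyond the scatter is therefore expected, a number 3.3 percentage points lower from compound 3 to compound 4 (within the scatter). Compound 4 is estimated at 27%, with a range from 10% to 45%.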

Compound 4, a percentage reported as activity, at one dose (the size of the read-out at that dose, not a potency): 32.3%
Compound 4: the middle estimate sits 5.3 percentage points below what was measured, within the range that was stated.
By their numbers in this assay, from the lowest: compounds 2, 3 and 4 (each within the scatter of the next); then compound 1.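

In this assay, hydrogen in place of isopropyl or carboxymethyl on this saturated chain carbon leaves the read-out within the scatter, with a number 2 percentage points higher from compound 3 to compound 4 (within the scatter) and a number 7.2 percentage points higher from compound 2 to compound 4 (within the scatter). Only 2-carboxyethyl stands apart from having no group here, with a number 12.4 percentage points lower from compound 1 to compound 4 (beyond the scatter), so a side group at this position is not needed to reach the level of compounds 2 and 3. Nothing measured here explains why 2-carboxyethyl differs. On these data alone, what an amine, or a chain longer than 2-carboxyethyl ending in a carboxylic acid, would do at this position remains open.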